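A Single Added Group on Compound 2

The compounds below may be only part of what the source reports. "The series", "measured", "known", "first", "only" and "open" are said of these compounds alone.

Within the data shown here, in a functional assay on L1210 cells (Mus musculus) (on this read-out lower numbers stand for stronger inhibition and higher numbers for weaker inhibition), only two compounds have numbers so far. Compound 2 `COc1ccc(C(=O)Oc2ccc(/C=C3\CCCCC3=O)cc2)cc1` gives 43400 nM as the higher of the two numbers, which puts it at the weak end. Compound 1 `CN(C)CC1CCC/C(=C\c2ccc(OC(=O)/C=C/c3ccc(F)cc3)cc2)C1=O` gives 1840 nM and so lies below compound 2 by a gap beyond the scatter.

Compound 3 `COc1ccc(C(=O)Oc2ccc(/C=C3\CCCC(CN(C)C)C3=O)cc2)cc1` differs from compound 2 in one place by (dimethylamino)methyl in place of hydrogen on a saturated ring carbon and the change is (dimethylamino)methyl in place of hydrogen on a saturated ring carbon. Compound 1 carries (dimethylamino)methyl too, but it also differs from compound 2 elsewhere, so the gap between their numbers cannot be assigned to that group alone. Among the measured compounds shown here, no measured pair isolates this change, and compound 1 is the only guide. With compound 1 at 1840 nM as that guide, a large move towards stronger inhibition is expected in this assay for this change. The estimated size of this move is a 17-fold lower number from compound 2 to compound 3 (1.24 log units; beyond the scatter) and it lies beyond the scatter. Compound 3 is expected to give about 2500 nM with an estimated range from 700 nM to 9000 nM in this measurement.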

Compound 3, half-maximal inhibitory concentration: 2870 nM
Beside the measured number, compound 3's estimate is 1.1-fold (0.06 log units) below it; low and high end bracket the measured number.
By their numbers in this assay, from the lowest: compounds 1 and 3 (each within the scatter of the next); then compound 2.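

In this assay, the (dimethylamino)methyl group in place of hydrogen on a saturated ring carbon now has a pair of its own, and a 15-fold lower number from compound 2 to compound 3 (1.18 log units; beyond the scatter) shows a large step that belongs to this one change, whereas compound 1 had carried the group alongside a second difference. With the group in place, the exchange of 4-methoxyphenyl for 2-(4-fluorophenyl)ethenyl on a carbonyl carbon gives a 1.6-fold higher number from compound 1 to compound 3 (0.19 log units; within the scatter) and so does not separate the two compounds on this read-out. Nothing measured here speaks to why the added group has so large an effect.

The compounds shown leave open whether the step needs the dimethylamino group as such, or whether a primary amine, a morpholine, a carboxylic acid or a longer chain on the same saturated ring carbon would give a similar number. They also leave open whether the step has the same size with 2-(4-fluorophenyl)ethenyl on the carbonyl carbon, as the partner of compound 1 without the added group is not among them.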